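A few compounds are considered here, and "the series" means these few. Any claim that something is new, unique, unknown or untested is made for them only; others in the source may bear on it.

Measured so far in an assay for inhibition of inositol hexakisphosphate kinase 2 (Homo sapiens), read by colorimetric assay, coupled enzyme assay and malachite green, with a stated time of 120 min, in the presence of a further agent that is not named here; on this read-out higher numbers stand for weaker inhibition and lower numbers for stronger inhibition:
- compound 1 `O=C(O)/C=C/c1ccc2noc(-c3ccc(-c4ccccc4)cc3)c2c1` gives 74 nM
- compound 2 `CNC(=O)c1ccc2noc(-c3ccccc3)c2c1` gives 2120 nM
- compound 3 `O=C(O)c1ccc2noc(-c3ccc(Cc4ccccc4)cc3)c2c1` gives 65 nM

Compound 3 holds the lowest number of the three. Its nearest neighbour is compound 1, whose number sits within the scatter of that of compound 3, so no order can be drawn between these two. Compound 2 lies far beyond the scatter from both, a much weaker inhibitor on this read-out; it is also the only one of the three that carries neither a carboxylic acid nor a further group on the phenyl of the shared core.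

The next compound, compound 4 `CC(C)C(=O)Nc1ccc(-c2onc3ccc(C(=O)O)cc23)cc1`, keeps the carboxylic acid of compound 3 and changes only the substituent on the pendant ring: (isopropylcarbonyl)amino in place of benzyl on an aromatic carbon. For the measured compounds named here, no pair of measured compounds shows this change directly, so the size of the step can only be guessed. Compound 1 and compound 3 show that two different para groups give numbers within the scatter of each other, while compound 2 with 2120 nM shows what happens when such a group is absent together with the acid. The step of a 3.1-fold higher number from compound 3 to compound 4 (0.49 log units; beyond the scatter) is expected to be a modest weakening, not far beyond the scatter. Compound 4 is estimated at 200 nM, within 60 nM to 700 nM.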

Compound 4, half-maximal inhibitory concentration: 820 nM
Compound 4: the middle estimate sits 4.1-fold (0.61 log units) below what was measured; the measured number lies above the stated range.
By their numbers in this assay, from the lowest: compounds 3 and 1 (each within the scatter of the next); then compound 4; then compound 2.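

On the aromatic carbon para to a large group, with the carboxylic acid kept in place, the step of a 13-fold higher number from compound 3 to compound 4 (1.10 log units; beyond the scatter) in this assay shows that this position does not accept every substituent equally: (isopropylcarbonyl)amino in place of benzyl costs a large part of the inhibition. For the compounds shown here, this is the first direct reading of a change at this position, and the exchange alters several things at once, as the ring of benzyl leaves while an entering group with no ring brings a double bond outside aromatic rings, a hydrogen-bond donor and a hydrogen-bond acceptor. Nothing available explains the size of this step.

Going by these compounds alone, the single step cannot tell whether the loss of the aromatic ring or the arrival of the amide accounts for the weaker inhibition. On these data alone, a benzoylamino group, which has both a ring and an amide, or an isobutyl chain, which has neither, on the same aromatic carbon would be needed to separate the two, and it remains open how either would compare with compound 3 and compound 4.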